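This account rests on a few compounds, and the source may have more. Where it says the series, first, only, none or still open, it means among the compounds named here.

Measured so far in a functional assay (plasma) for inhibition, with Oryctolagus cuniculus as the target; on this read-out lower numbers stand for stronger inhibition and higher numbers for weaker inhibition:
- compound 1, `Cc1ccc(S(=O)(=O)N[C@H]2C3CC[C@H](C3)[C@@H]2C/C=C\CCCC(=O)O)cc1`: 500 nM
- compound 2, `Cc1ccccc1S(=O)(=O)N[C@H]1C2CC[C@H](C2)[C@@H]1C/C=C\CCCC(=O)O`: 6200 nM
- compound 3, `O=C(O)CCC/C=C\C[C@H]1[C@@H]2CCC(C2)[C@@H]1NS(=O)(=O)Cc1ccccc1`: 113000 nM

Compound 1 gives the lowest number of the three in this assay. Compound 2 follows at a 12-fold higher number from compound 1 to compound 2 (1.09 log units; beyond the scatter), and compound 3 stands furthest away at a 230-fold higher number from compound 1 to compound 3 (2.35 log units; beyond the scatter); between those two, the shift from compound 2 to compound 3 is an 18-fold higher number from compound 2 to compound 3 (1.26 log units; beyond the scatter). All three steps alter only the group on the sulfonyl sulfur and all are large, so this assay is clearly sensitive to what sits on that sulfur.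

Compound 4, `O=C(O)CCC/C=C\C[C@H]1[C@@H]2CCC(C2)[C@@H]1NS(=O)(=O)c1ccc(C(=O)O)cc1`, keeps the 4-methylphenyl pattern of compound 1 but carries a different substituent there: carboxy in place of methyl on an aromatic carbon. Among the compounds with values here, no measured step exchanges one group for another on the same ring position, so the measured steps only show that changes at the sulfonyl end can move the number far; they give no direction for a carboxy. A moderate weakening is therefore expected, a 3.0-fold higher number from compound 1 to compound 4 (0.48 log units; beyond the scatter), with wide uncertainty. Compound 4 is estimated at 1500 nM, between 300 nM and 8000 nM.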

Compound 4, half-maximal inhibitory concentration: 800000 nM
Compound 4: the middle estimate sits 530-fold (2.73 log units) below what was measured; measured number outside the range, above it.
By their numbers in this assay, from the lowest: compound 1; then compound 2; then compound 3; then compound 4.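

In this assay, within the data shown here, carboxy in place of methyl on the aromatic carbon gives the largest step yet (a 1600-fold higher number from compound 1 to compound 4 (3.20 log units; beyond the scatter)), so one substituent at this place on the ring moves the number further than any exchange of the whole sulfonyl substituent among the earlier compounds. Compound 4 also lies past compound 3 (a 7.1-fold higher number from compound 3 to compound 4 (0.85 log units; beyond the scatter)) and past compound 2 (a 130-fold higher number from compound 2 to compound 4 (2.11 log units; beyond the scatter)), so a ring bonded directly to the sulfonyl sulfur does not by itself keep the number low. No measurement on hand explains this rise.

As far as these compounds go, it remains open whether the loss belongs to the carboxylic acid itself or would also follow a methyl ester, a primary amide or a hydroxymethyl group at this place. Also open, from the compounds shown here alone, is how a methyl ester or a chlorine at this place would compare with the methyl of compound 1.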